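The source may report more compounds than this note shows. Statements on the series, on what has been measured and on what is new or still open speak of the compounds shown alone.

Measured so far in a functional assay on the whole organism for agonist activity, with Mus musculus as the target; on this read-out higher numbers stand for an effect only at larger amounts of compound and lower numbers for an effect already at smaller amounts:
compound 1 `CN(C)CC#CCN1CCNC1=O` gives 9.7 mg/kg
compound 2 `CN1CCN(CC#CCn2ccnc2)C1=O` gives 0.97 mg/kg

Compound 2 holds the lower of the two numbers, and compound 1 at 9.7 mg/kg lies above it, beyond the scatter. The move to compound 3 `CN(C)CC#CCN1CCN(C)C1=O` puts dimethylamino in place of 1H-imidazol-1-yl on a saturated chain carbon bound to a triple-bonded carbon. Within the data shown here, no measured step covers this change. Compound 1 (9.7 mg/kg) also carries dimethylamino, so a higher number than that of compound 2 is expected in this assay, beyond the scatter. The estimated step runs a 4.1-fold higher number from compound 2 to compound 3 (0.62 log units; beyond the scatter) in that direction. For compound 3 the estimate is 4 mg/kg, with an expected range from 1 mg/kg to 18 mg/kg at the upper end.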

Compound 3, dose for half-maximal effect: 0.37 mg/kg
Compound 3: middle estimate off by 11-fold (1.03 log units), on the high side, outside the stated range (below it).
By their numbers in this assay, from the lowest: compound 3; then compound 2; then compound 1.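

In this assay, with the methyl on the amide-type nitrogen in the ring held constant, dimethylamino in place of 1H-imidazol-1-yl on a saturated chain carbon bound to a triple-bonded carbon gives a 2.6-fold lower number from compound 2 to compound 3 (0.42 log units; beyond the scatter) and so favours the open-chain group. That methyl in place of hydrogen gives the larger change, a 26-fold lower number from compound 1 to compound 3 (1.42 log units; beyond the scatter) in the same assay, making this ring nitrogen a strong lever on the number. No evidence at hand gives a cause for either step.

On these data alone, whether diethylamino or a pyrrolidin-1-yl ring at the chain carbon would keep the number this low remains open. So does the effect of an ethyl group on the ring nitrogen.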